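A few compounds are considered here, and "the series" means these few. Any claim that something is new, unique, unknown or untested is made for them only; others in the source may bear on it.

Compound 1 `Cc1ccc(Nc2nnc(Nc3nc(-c4ccc(Br)cc4)cs3)s2)cc1`: 300 mg/kg
Compound 2 `Cc1ccc(Nc2nnc(Nc3nc(-c4ccccc4)cs3)s2)cc1`: 300 mg/kg

Both measured compounds were tested in a functional assay on the whole organism (strain albino) with Mus musculus as the target, with a stated time of 0.5 h; a lower number here means that less compound is needed, a higher number that more compound is needed for the effect. Compound 1 gives 300 mg/kg, and compound 2 gives 300 mg/kg. For the measured compounds named here, the only measured step, no change at the digits printed from compound 1 to compound 2 (within the scatter), concerns hydrogen in place of bromo on an aromatic carbon, so compound 2 stands level with compound 1, with no change within the scatter.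

Compound 3 `COc1ccccc1Nc1nnc(Nc2nc(-c3ccccc3)cs2)s1` differs from compound 2 by 2-methoxyphenyl in place of 4-methylphenyl on a nitrogen on an aromatic ring. Going by the values given here, this change sits on a nitrogen on an aromatic ring, a part of the shared core that the single measured step does not touch, so no measured step bears directly on it. Among the compounds with values here, the one step that exists was flat, and nothing else points in either direction. The expected outcome is therefore no shift beyond the scatter, with the estimated step of no change at the digits printed from compound 2 to compound 3 (within the scatter). Compound 3 is estimated at 300 mg/kg, with a range from 100 mg/kg to 1000 mg/kg.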

Compound 3, minimum effective dose: 100 mg/kg
Compound 3: middle estimate off by 3.0-fold (0.48 log units), on the high side; the measured number falls inside the stated range.
By their numbers in this assay, from the lowest: compound 3; then compounds 1 and 2 (each within the scatter of the next).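

Putting 2-methoxyphenyl in place of 4-methylphenyl on the nitrogen gives a 3.0-fold lower number from compound 2 to compound 3 (0.48 log units; beyond the scatter) in this assay and so means that less compound is needed for the effect. The step is modest, but it shows that this position can move the dose, whereas the bromo-to-hydrogen change elsewhere on the molecule gave no change at the digits printed from compound 1 to compound 2 (within the scatter) and did not. The entering group brings an oxygen and a hydrogen-bond acceptor that the leaving group lacks, but nothing available here explains why the number moved.

The change swaps the kind of group and its place on the ring in a single move, so the contribution of each stays unresolved. A 2-methylphenyl or 4-methoxyphenyl group on the same nitrogen would separate the two, and a plain phenyl group would show the effect of having no substituent at all.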